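This account rests on a few compounds, and the source may have more. Where it says the series, first, only, none or still open, it means among the compounds named here.

Measured values in an ADME assay on microsomes from liver (Homo sapiens) for pharmacokinetics, read by LC-MS, using NADPH, with a stated time of 45 min, tested at 1 uM (on this read-out lower numbers stand for slow clearance and higher numbers for fast clearance), are these:
Compound 1 `COc1cc(OCc2ccnc(N)c2Cl)cc2sc(N[C@@H]3CCCC[C@H]3O)nc12` gives 38 mL/min/kg
Compound 2 `COc1cc(OCc2ccnc(N)n2)cc2sc(N[C@@H]3CCCC[C@H]3O)nc12` gives 10 mL/min/kg

Compound 2 holds the lower of the two numbers, and it is the starting point here. Compound 3 `COc1cc(OCc2ccnc(N)n2)cc2sc(N[C@H]3CCCC[C@@H]3O)nc12` relates to compound 2 as follows: the two compounds have the same atoms and bonds and differ only in configuration as drawn: 2 of 2 stereo elements differ (all stereocentres are inverted: mirror images); a stereocentre at a saturated ring carbon is drawn R in compound 2 and S in compound 3; a stereocentre at a saturated ring carbon is drawn R in compound 2 and S in compound 3 and nothing leaves or enters. Within the data shown here, the one measured step of a 3.8-fold lower number from compound 1 to compound 2 (0.58 log units; beyond the scatter) comes from 2-aminopyrimidin-4-yl in place of 2-amino-3-chloropyridin-4-yl and leaves the configuration unchanged, so it bears only weakly on this change. Among the measured compounds shown here, no pair of mirror images has been measured. No step beyond the scatter is therefore expected in this assay and no direction can be favoured. The estimated step is a 1.2-fold higher number from compound 2 to compound 3 (0.08 log units; within the scatter) and it is expected to stay small. For compound 3 the expected clearance is 12 mL/min/kg with an estimated range from 6 mL/min/kg to 24 mL/min/kg as its likely span.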

Compound 3, clearance: 9.5 mL/min/kg
Compound 3: the middle estimate sits 1.3-fold (0.10 log units) above what was measured, and the stated range covers the measured number.
By their numbers in this assay, from the lowest: compounds 3 and 2 (each within the scatter of the next); then compound 1.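

In this assay, among these compounds, inverting both stereocentres on the saturated ring gives a 1.1-fold lower number from compound 2 to compound 3 (0.02 log units; within the scatter), the first measured step that concerns configuration rather than the aromatic group on the oxygen-bound chain carbon. For this pair, the read-out therefore does not separate the two mirror-image forms, so the configuration as drawn has no visible bearing on clearance here. Any reading of this step concerns stereochemistry alone, with no substituent change mixed in: the fact that compounds 2 and 3 differ only in the configuration as drawn

The compounds shown leave open whether the same indifference holds when the 2-amino-3-chloropyridin-4-yl group replaces 2-aminopyrimidin-4-yl, or when only one of the two stereocentres is inverted. They also do not tell what clearance would follow if an amine or a methoxy group stood in place of the hydroxyl on the saturated ring.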